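From a Bromophenyl Limit to an Aminophenyl Estimate

A few compounds are considered here, and "the series" means these few. Any claim that something is new, unique, unknown or untested is made for them only; others in the source may bear on it.

Compound 1 `COc1cc(-c2cccc3nc(-c4cccc(F)c4)oc23)cc(OC)c1OC`: 2600 nM
Compound 2 `COc1cc(-c2cccc3nc(-c4ccc(Br)cc4)oc23)cc(OC)c1OC`: > 25000 nM, a limit and not a number
Compound 3 `COc1cc(-c2cccc3nc(-c4ccc(C)cc4)oc23)cc(OC)c1OC`: 680 nM

All three were tested in a functional assay on A549 cells (Homo sapiens) for antiproliferative activity, read by MTT assay, with a stated time of 48 h; a higher number here means a weaker inhibitor, a lower number a stronger inhibitor. Compound 2 sits at the limit of > 25000 nM in this assay, at which 1 of the 3 values shown sits.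

Compound 4 `COc1cc(-c2cccc3nc(-c4cccc(N)c4)oc23)cc(OC)c1OC` carries 3-aminophenyl in place of 4-bromophenyl on an aromatic carbon.

Two measured steps leave the same group. The first, an at least 9.6-fold higher number from compound 1 to compound 2 (0.98 log units; beyond the scatter), read in reverse, is at least modest, and the second, an at least 36-fold lower number from compound 2 to compound 3 (1.56 log units; beyond the scatter), is large. Both other groups gave real numbers, so a large fall is expected here too, landing close to compound 1 at 2600 nM. The expected change is an at least 13-fold lower number from compound 2 to compound 4 (1.14 log units; beyond the scatter). For compound 4 the estimate is 1800 nM, with an expected range of 300 nM to 12000 nM.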

Compound 4, half-maximal inhibitory concentration: 4700 nM
Estimate against measurement, compound 4: 2.6-fold (0.42 log units) below; low and high end bracket the measured number.
By their numbers in this assay, from the lowest: compound 3; then compounds 1 and 4 (each within the scatter of the next). At a limit, above all of these: compound 2.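

The 3-aminophenyl group gives a second escape from compound 2, whose value is a limit and not a number (an at least 5.3-fold lower number from compound 2 to compound 4 (0.72 log units; beyond the scatter)). Amino and fluoro on this ring cannot be told apart (a 1.8-fold higher number from compound 1 to compound 4 (0.26 log units; within the scatter)), so a real number here does not depend on a single group. The 4-methylphenyl group stays clearly ahead (a 6.9-fold higher number from compound 3 to compound 4 (0.84 log units; beyond the scatter)), but that step changes both the group and its place on the ring.

Still open, on these data alone, is whether 3-methylphenyl or 4-aminophenyl would match compound 3 or compound 4, which would separate the effect of the group from that of its place.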